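Swapping the imine aryl for furan on a hydrazone core

The source may report more compounds than this note shows. Statements on the series, on what has been measured and on what is new or still open speak of the compounds shown alone.

Of the compounds shown here, three sharing one core have been measured. Compound 1 `O=C(N/N=C/c1ccco1)c1cc(-c2ccccc2)nn1Cc1ccccc1` gives 12500 nM in a functional assay on A549 cells (Homo sapiens) for cytotoxicity, read by MTT assay, with a stated time of 48 h; a higher number here means a more soluble compound, a lower number a less soluble compound. Compound 2 `O=C(N/N=C/c1ccccc1O)c1cc(-c2ccccc2)nn1Cc1ccc(Cl)nc1` gives 45000 nM. Compound 3 `COc1ccc(/C=N/NC(=O)c2cc(-c3ccccc3)nn2Cc2ccc(Cl)nc2)cc1` gives 15000 nM, which puts compound 3 second highest of the three: its nearest neighbour is compound 1, a touch lower but within the scatter, while compound 2 sits clearly higher.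

Compound 4 `O=C(N/N=C/c1ccco1)c1cc(-c2ccccc2)nn1Cc1ccc(Cl)nc1` is the next candidate. Its change from compound 3 is furan-2-yl in place of 4-methoxyphenyl on a carbon with a double bond to nitrogen. For the measured compounds named here, only one measured step touches the same position: a 3.0-fold lower number from compound 2 to compound 3 (0.48 log units; beyond the scatter), where one aryl group replaced another on that carbon. That step was modest. Compound 4 also shares its furan-2-yl group and the rest of the imine side with compound 1, which differs from compound 4 only in the group on the ring nitrogen, and compound 1 and compound 3 are within the scatter of each other.

Taken together, the step from compound 3 to compound 4 is expected to stay within the scatter, a 1.2-fold lower number from compound 3 to compound 4 (0.06 log units; within the scatter). Compound 4 is therefore estimated at 13000 nM, with a range from 6000 nM to 28000 nM.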

Compound 4, solubility: 50000 nM
For compound 4 the middle estimate is 3.8-fold (0.59 log units) below the measured one; the whole stated range lies below it.
By their numbers in this assay, from the lowest: compounds 1 and 3 (each within the scatter of the next); then compounds 2 and 4 (each within the scatter of the next).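

The furan-2-yl group makes a clear difference on the carbon with a double bond to nitrogen: in this assay, with the 6-chloropyridin-3-yl group held fixed, there is a 3.3-fold higher number from compound 3 to compound 4 (0.52 log units; beyond the scatter). The earlier step at this place showed only a fall from the 2-hydroxyphenyl group to the 4-methoxyphenyl group, whereas a 1.1-fold higher number from compound 2 to compound 4 (0.05 log units; within the scatter) now shows that two quite different groups, furan-2-yl and 2-hydroxyphenyl, can give numbers that cannot be told apart. For the compounds shown here, compound 4 also gives the first single-place comparison at the other site, a saturated chain carbon bound to an aromatic nitrogen, where with furan-2-yl held fixed, 6-chloropyridin-3-yl in place of phenyl gives a 4.0-fold higher number from compound 1 to compound 4 (0.60 log units; beyond the scatter).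

The compounds shown leave open whether that gain at the chain carbon would also appear with 4-methoxyphenyl or 2-hydroxyphenyl on the imine carbon, and where a thiophene ring or a phenyl ring carrying an amine would fall at that place. Nothing available here accounts for the size or direction of any of these steps.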